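This account rests on a few compounds, and the source may have more. Where it says the series, first, only, none or still open, it means among the compounds named here.

Going by the values given here, in a functional assay on DU-145 cells (Homo sapiens) for cytotoxicity, read by ELISA, with a stated time of 2 days (a higher number here means a weaker inhibitor, a lower number a stronger inhibitor), compound 1 `Oc1cccc(-c2cc(-c3ccccc3)cc(-c3ccccc3)n2)c1` gives 18000 nM and compound 2 `Oc1cccc(-c2cc(-c3ccccc3)cc(-c3cccs3)n2)c1` gives 18900 nM, so compound 2 stands within the scatter of the only other number. Compound 3 `Oc1cccc(-c2cc(-c3ccccc3)cc(-c3ccsc3)n2)c1` has thiophen-3-yl in place of thiophen-2-yl on an aromatic carbon, next to the ring nitrogen: thiophen-3-yl in place of thiophen-2-yl on an aromatic carbon. Among the compounds with values here, the one measured step that bears on this, a 1.1-fold higher number from compound 1 to compound 2 (0.02 log units; within the scatter), replaced phenyl with thiophen-2-yl at that same place, so no change beyond the scatter is expected in this assay. The expected step is a 1.0-fold lower number from compound 2 to compound 3 (0.01 log units; within the scatter). Compound 3 is estimated at 18500 nM, with an expected range of 11000 nM to 30000 nM.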

Compound 3, half-maximal inhibitory concentration: 11700 nM
Estimate against measurement, compound 3: 1.6-fold (0.20 log units) above; the measured number falls inside the stated range.
By their numbers in this assay, from the lowest: compounds 3, 1 and 2 (each within the scatter of the next).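

In this assay the two thiophene attachments at this position, on an aromatic carbon next to the ring nitrogen, cannot be told apart: thiophen-3-yl in place of thiophen-2-yl gives (a 1.6-fold lower number from compound 2 to compound 3 (0.21 log units; within the scatter)). Thiophen-3-yl in place of phenyl gives (a 1.5-fold lower number from compound 1 to compound 3 (0.19 log units; within the scatter)), so all three groups now read alike at this place. No measured property bears on this result.

As far as these compounds go, whether an amine or a carboxylic acid here would shift the number beyond the scatter remains open. So does the contribution of the 3-hydroxyphenyl group.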